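This account rests on a few compounds, and the source may have more. Where it says the series, first, only, none or still open, it means among the compounds named here.

Working notes. Compounds 1, 2 and 3 share one core and differ only in the group on the triple-bonded carbon: compound 1 `CNC(=O)[C@@]12C[C@@H]1[C@@H](n1cnc3c(NC)nc(C#Cc4ccc(-c5ccccc5)cc4)nc31)[C@H](O)[C@@H]2O`, compound 2 `CNC(=O)[C@@]12C[C@@H]1[C@@H](n1cnc3c(NC)nc(C#Cc4ccccc4F)nc31)[C@H](O)[C@@H]2O` and compound 3 `CNC(=O)[C@@]12C[C@@H]1[C@@H](n1cnc3c(NC)nc(C#Cc4ccc(Cl)cc4)nc31)[C@H](O)[C@@H]2O`. In an assay on CHO cells for displacement of a labelled ligand from adenosine receptor A1 (Homo sapiens), read by scintillation counting, with a stated time of 60 min, tested at 10 uM (on this read-out higher numbers stand for more inhibition at the one concentration tested (going by the name of the read-out) and lower numbers for less inhibition), compound 1 gives 18%, compound 2 gives 20% and compound 3 gives 13%. Compound 3 stands lowest of the three numbers, yet the steps of a number 5 percentage points lower from compound 1 to compound 3 (within the scatter) and a number 7 percentage points lower from compound 2 to compound 3 (within the scatter) are both within the scatter, as is a number 2 percentage points higher from compound 1 to compound 2 (within the scatter); none of the three exchanges of the aryl group has shifted the read-out beyond the scatter.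

Compound 4 `CNC(=O)[C@@]12C[C@@H]1[C@@H](n1cnc3c(NC)nc(C#Cc4cc5ccccc5o4)nc31)[C@H](O)[C@@H]2O` carries the change (1-benzofuran-2-yl in place of 4-chlorophenyl on a triple-bonded carbon). Within the data shown here, no measured step brings in a 1-benzofuran-2-yl group, so the only steps that bear on it are the three aryl exchanges, each small. On that basis no step beyond the scatter is expected. The estimated step is a number 4 percentage points higher from compound 3 to compound 4 (within the scatter). Compound 4 is expected to give 17%, with a range from 4% to 33%.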

Compound 4, a percentage reported as inhibition, at one concentration (the size of the read-out at that concentration, not a potency): 13%
Compound 4: middle estimate off by 4 percentage points, on the high side; the range from low to high includes it.
By their numbers in this assay, from the lowest: compounds 3, 4, 1 and 2 (each within the scatter of the next).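

Among these compounds, with 1-benzofuran-2-yl on the triple-bonded carbon, a five-membered aromatic ring with a hetero atom and a hydrogen-bond acceptor enter this position for the first time, yet in this assay the read-out stays within the scatter of all three earlier compounds (there is no change at the digits printed from compound 3 to compound 4 (within the scatter) and also a number 7 percentage points lower from compound 2 to compound 4 (within the scatter) and a number 5 percentage points lower from compound 1 to compound 4 (within the scatter)). The position therefore accepts this change of aromatic group without a step beyond the scatter, and the four compounds cannot be ranked on this read-out. No available evidence bears on this result.

On these data alone, whether an amine, a carboxylic acid or a longer alkyl chain on the triple-bonded carbon would move the read-out beyond the scatter remains open. The single test concentration also leaves the potency of all four compounds open.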